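The source may hold more compounds than are shown below. What is called first, only, known or untested is meant among the compounds shown, and "the series" means these compounds.

Measured so far:
Compound 1, `C#CCSc1nc(Nc2cccc(C(F)(F)F)c2)c(C#N)c(-c2ccccc2)n1`, gives 61100 nM in a functional assay on B16-F10 cells (Mus musculus) for inhibition, read by MTT assay, with a stated time of 72 h; on this read-out lower numbers stand for stronger inhibition and higher numbers for weaker inhibition.
Compound 2, `C#CCSc1nc(Nc2ccc(Cl)cc2)c(C#N)c(-c2ccccc2)n1`, gives 19800 nM in this assay.
Compound 3, `N#Cc1c(Nc2ccccc2Cl)nc(SCc2cn(Cc3ccccc3Cl)nn2)nc1-c1ccccc1`, gives 8350 nM in this assay.

Compound 3 stands at the lowest of the three numbers. Compound 2 gives a number that lies above it by more than the scatter, and compound 1 lies further above still. Compounds 1 and 2 differ from compound 3 in more than one place, so their values show only where they fall and isolate no single change.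

Compound 4, `N#Cc1c(Nc2ccc(F)cc2)nc(SCc2cn(Cc3ccccc3Cl)nn2)nc1-c1ccccc1`, has not yet been measured in this assay. It differs from compound 3 in one place: 4-fluorophenyl in place of 2-chlorophenyl on a nitrogen on an aromatic ring. Among the compounds with values here, no measured pair shows a change of this kind on its own, so the expectation rests on compound 3 alone. A modest shift is expected, if anything toward a slightly higher number, and the step from compound 3 to compound 4 is expected to be a 1.4-fold higher number from compound 3 to compound 4 (0.16 log units; within the scatter), not clearly beyond the scatter. Compound 4 is therefore estimated at 12000 nM, with a range from 4000 nM to 40000 nM.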

Compound 4, half-maximal inhibitory concentration: 5340 nM
Beside the measured number, compound 4's estimate is 2.2-fold (0.35 log units) above it; measured number inside the range.
By their numbers in this assay, from the lowest: compounds 4 and 3 (each within the scatter of the next); then compound 2; then compound 1.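

In this assay, within the data shown here, 4-fluorophenyl in place of 2-chlorophenyl on a nitrogen on an aromatic ring gives a 1.6-fold lower number from compound 3 to compound 4 (0.19 log units; within the scatter), the first comparison here that isolates a single change. At this position, the two halogen-bearing phenyl groups therefore cannot be told apart on this read-out, something that compound 1 and compound 2 could not show, as each differs from compound 3 and compound 4 in more than one place. Nothing measured here bears on why the two groups read alike.

The compounds shown leave open how an unsubstituted phenyl, a 4-methoxyphenyl or a phenyl carrying a carboxylic acid would read on this nitrogen. They also leave open whether this exchange would read the same with the side chain on sulfur found in compound 1 and compound 2.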